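A few compounds are considered here, and "the series" means these few. Any claim that something is new, unique, unknown or untested is made for them only; others in the source may bear on it.

Working notes on the series, following the step from compound 3 to compound 4.

In a functional assay on A-375 cells (Homo sapiens) for antiproliferative activity (a lower number here means a stronger inhibitor, a higher number a weaker inhibitor), compound 3 `O=C(Nc1ccc(-c2cscn2)cc1)C1CCCN(Cc2ccccc2F)C1` gives 4000 nM. Compound 2 `O=C(Nc1ccc(-c2cscn2)cc1)[C@H]1CCCN(Cc2ccc(F)c(F)c2)C1` gives 190 nM, so compound 3 holds the higher of the two numbers, and the gap lies beyond the scatter. Compound 1 `O=C(Nc1ccc2scnc2c1)C1CCCN(Cc2ccc(F)c(F)c2)C1` is recorded at > 20000 nM, which is a limit of the assay and not a number.

The next compound is compound 4 `O=C(Nc1ccc(-c2cscn2)cc1)C1CCCN(Cc2cccc(F)c2F)C1`. It keeps compound 3 except on the benzyl group, where 2-fluorobenzyl becomes 2,3-difluorobenzyl: fluoro in place of hydrogen on an aromatic carbon. The new fluoro group sits on an aromatic carbon, ortho to the existing fluoro group and meta to a large group.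

Going by the values given here, no measured pair isolates a single change of this kind, so the size of the step has to be judged loosely. Among the compounds with values here, the one guide is that compound 2, which also carries two fluoro groups on its benzyl ring, reaches 190 nM, though it differs from compound 3 in more than the fluoro count. A modest move toward a lower number is therefore expected, only slightly beyond the scatter, and no change at all remains possible. The expected step is a 2.7-fold lower number from compound 3 to compound 4 (0.43 log units; beyond the scatter). For compound 4 the estimated value is 1500 nM, with an expected range of 300 nM to 7000 nM.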

Compound 4, half-maximal inhibitory concentration: 1480 nM
The estimate for compound 4 lay 1.0-fold (0.01 log units) above the measured number; the measured number falls inside the stated range.
By their numbers in this assay, from the lowest: compound 2; then compound 4; then compound 3. At a limit, above all of these: compound 1.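

Going by these compounds alone, the step is the first that isolates a single change: in this assay, fluoro in place of hydrogen on an aromatic carbon of the benzyl group gives a 2.7-fold lower number from compound 3 to compound 4 (0.43 log units; beyond the scatter), a modest move. This shows that the position ortho to the existing fluoro group and meta to a large group tolerates a fluoro group, and that 2,3-difluorobenzyl gives a lower number than 2-fluorobenzyl on this core, something compound 1 and compound 2 could not show because neither forms a single-place pair with compound 3. Nothing measured here bears on the reason for this step.

Whether the lower number belongs to fluoro specifically or would also follow from another group at this position stays open, since a chloro, methyl, methoxy or hydroxyl group there is not among the compounds shown. Within the data shown here, also open is whether the same change would give a step of similar size without the existing fluoro group, or on a core other than the one shared by compound 3 and compound 4.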